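This account rests on a few compounds, and the source may have more. Where it says the series, first, only, none or still open, it means among the compounds named here.

Measured compounds:
Compound 1 `CN[C@@H](CC(C)C)CN(C(=O)[C@@H]1C[C@H]1c1ccccc1)c1ccc(-c2ccccc2)cc1` gives in a functional assay for agonist activity at G protein-coupled receptor 88 (Homo sapiens), read by HTRF and cAMP accumulation (a higher number here means that more compound is needed for the effect, a lower number that less compound is needed), 2 nM.
Compound 2 `CC(C)(N)CN(C(=O)[C@@H]1C[C@H]1c1ccccc1)c1ccc(-c2ccccc2)cc1` gives in this assay 1.4 nM.

Within the data shown here, compound 2 holds the lower of the two numbers, but its only neighbour, compound 1, lies within the scatter: the step of a 1.4-fold lower number from compound 1 to compound 2 (0.15 log units; within the scatter) is no larger than repeated measurement would produce. Compound 3 `CCC(C)CNCCN(C(=O)[C@@H]1C[C@H]1c1ccccc1)c1ccc(-c2ccccc2)cc1` has not been measured in this assay. It differs from compound 2 in that (((2-methylbutyl)amino)methyl in place of 1-amino-1-methylethyl on a saturated chain carbon bound to an amide-type nitrogen). Among the measured compounds shown here, the one measured step that bears on this change is a 1.4-fold lower number from compound 1 to compound 2 (0.15 log units; within the scatter), in which the amine-bearing substituent on the same saturated chain carbon was exchanged without a shift beyond the scatter. The group entering in compound 3 is larger than the one it replaces and the exchange is wider than the measured one, so the expectation rests on a single observation that this position tolerates exchange, with room for a modest rise in the number. For compound 3 the expected step is a 2.1-fold higher number from compound 2 to compound 3 (0.33 log units; beyond the scatter), without a firm direction. The estimate for compound 3 is 3 nM, with a range from 1 nM to 12 nM.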

Compound 3, half-maximal effective concentration: 4.7 nM
Compound 3: the middle estimate sits 1.6-fold (0.19 log units) below what was measured; the measured number falls inside the stated range.
By their numbers in this assay, from the lowest: compounds 2 and 1 (each within the scatter of the next); then compound 3.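

In this assay the place on a saturated chain carbon bound to an amide-type nitrogen now shows its first exchange beyond the scatter: ((2-methylbutyl)amino)methyl brings a 3.4-fold higher number from compound 2 to compound 3 (0.53 log units; beyond the scatter), and set against the group of compound 1 the same substituent brings a 2.4-fold higher number from compound 1 to compound 3 (0.37 log units; beyond the scatter). The amine-bearing groups at this place are therefore not all interchangeable, although both steps are modest and the larger ((2-methylbutyl)amino)methyl is accepted with only a limited rise in the number. Nothing available here accounts for that rise.

The change from 2-amino-2-methylpropyl to 2-((2-methylbutyl)amino)ethyl alters several features at once, so the compounds shown do not tell whether the rise follows the 2-methylbutyl group on the nitrogen or the loss of the branched carbon that carries the amine in compound 2. A plain 2-aminoethyl chain would separate those two features, and a hydroxyl group or a carboxylic acid in place of the amine would show whether any nitrogen is needed at this place at all.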